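The compounds below may be only part of what the source reports. "The series", "measured", "known", "first", "only" and "open" are said of these compounds alone.

Measured compounds:
compound 1 `O=S(=O)(Oc1cccc2cccnc12)c1ccccc1` gives 49500 nM in an assay for inhibition of beta-glucuronidase (Bos taurus), read by spectrophotometry, with a stated time of 30 min; on this read-out higher numbers stand for weaker inhibition and lower numbers for stronger inhibition;
compound 2 `O=[N+]([O-])c1cccc(S(=O)(=O)Oc2cccc3cccnc23)c1` gives 30100 nM in this assay;
compound 3 `O=[N+]([O-])c1ccc(S(=O)(=O)Oc2cccc3cccnc23)cc1` gives 15400 nM in this assay.

Compound 1 carries no substituent on its sulfonyl-bearing ring and has the highest number of the three, meaning the weakest inhibition; compound 2 sits nearest to it and compound 3 furthest away. Compounds 2 and 3 each carry a single nitro group on that ring, so both serve as precedents for the same kind of change.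

Compound 4 `O=[N+]([O-])c1ccccc1S(=O)(=O)Oc1cccc2cccnc12` differs from compound 1 by nitro in place of hydrogen on an aromatic carbon. The two measured steps of the same kind are a 1.6-fold lower number from compound 1 to compound 2 (0.22 log units; within the scatter) and a 3.2-fold lower number from compound 1 to compound 3 (0.51 log units; beyond the scatter). One of them stays within the scatter and the other is a modest lowering, so adding a nitro group to this ring has so far given numbers that are the same or somewhat lower, never higher. On that basis compound 4 is expected to give a number somewhat below compound 1, by about a 2.0-fold lower number from compound 1 to compound 4 (0.30 log units; within the scatter), with the step possibly staying within the scatter. The estimate for compound 4 in this assay is 25000 nM, with a range from 10000 nM to 60000 nM.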

Compound 4, half-maximal inhibitory concentration: 6400 nM
For compound 4 the middle estimate is 3.9-fold (0.59 log units) above the measured one, outside the stated range (below it).
By their numbers in this assay, from the lowest: compound 4; then compounds 3, 2 and 1 (each within the scatter of the next, the first and the last beyond it).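

On the ring of compound 1, nitro ortho to a large group gives a 7.7-fold lower number from compound 1 to compound 4 (0.89 log units; beyond the scatter) in this assay, so this position joins compound 3 in a lowering beyond the usual scatter, while the step to compound 2 stays within it. Compound 4 and compound 3 lie within the scatter of each other, so these two placements of the nitro group cannot be ranked, but with compound 4 a nitro group has now given no higher number than compound 1 at any of the three ring positions shown, and the number for compound 4 is clearly separated from that of compound 1. No measurement shown here accounts for this lowering or says what the nitro group does at this position.

The compounds shown leave open whether this lowering belongs to nitro itself or would also appear with another group in the same place, such as an amine, a carboxylic acid or a methyl group. They also leave open what a second nitro group on the same ring would do to the number.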